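This account rests on a few compounds, and the source may have more. Where it says the series, first, only, none or still open, it means among the compounds named here.

Measured so far in an assay on CHO cells for displacement of a labelled ligand from 5-hydroxytryptamine receptor 7 (Homo sapiens); a lower number here means a stronger inhibitor, a higher number a weaker inhibitor:
compound 1 `CCC1(CCCCN2CCN(c3ccccc3)CC2)C(=O)Nc2ccccc21`, 2.07 nM
compound 2 `CCC1(CCCCN2CCN(c3ccc(OC)cc3)CC2)C(=O)Nc2ccccc21`, 25.4 nM
compound 3 `CCC1(CCCCN2CCN(c3ccccc3Cl)CC2)C(=O)Nc2ccccc21`, 5.11 nM

All three share the same core and differ only in the phenyl ring that sits on the piperazine nitrogen. Compound 3 stands second highest of the three numbers: it lies closest to compound 1, as shown by a 2.5-fold higher number from compound 1 to compound 3 (0.39 log units; beyond the scatter), and furthest from compound 2, as shown by a 5.0-fold lower number from compound 2 to compound 3 (0.70 log units; beyond the scatter).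

Compound 4 `CCC1(CCCCN2CCN(c3ccc(Cl)c(Cl)c3)CC2)C(=O)Nc2ccccc21` has not yet been measured. The change from compound 3 is 3,4-dichlorophenyl in place of 2-chlorophenyl on an amine nitrogen in a ring.

Among the measured compounds shown here, two measured steps bear on this. Both start from the bare phenyl of compound 1: adding a methoxy gave a 12-fold higher number from compound 1 to compound 2 (1.09 log units; beyond the scatter), and adding a chloro gave a 2.5-fold higher number from compound 1 to compound 3 (0.39 log units; beyond the scatter). In each case a substituent on the phenyl raised the number. For the measured compounds named here, compound 4 carries two chlorines on that ring rather than one, and no measured step tells how a second chlorine, or chlorines at these positions, acts. A further modest rise in this assay is therefore expected rather than a fall.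

Compound 4 is estimated at 12 nM, within a range of 3.5 nM to 45 nM, which means an expected step of a 2.3-fold higher number from compound 3 to compound 4 (0.37 log units; beyond the scatter).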

Compound 4, inhibition constant: 0.63 nM
For compound 4 the middle estimate is 19-fold (1.28 log units) above the measured one; measured number outside the range, below it.
By their numbers in this assay, from the lowest: compound 4; then compound 1; then compound 3; then compound 2.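

In this assay, a substituted phenyl on this amine nitrogen need not weaken binding: 3,4-dichlorophenyl in place of the bare phenyl gives a 3.3-fold lower number from compound 1 to compound 4 (0.52 log units; beyond the scatter) and so goes against the rise seen with the substituents of compound 2 and compound 3. The pattern of the ring matters as much as the presence of a substituent, since moving from 2-chlorophenyl to 3,4-dichlorophenyl brings an 8.1-fold lower number from compound 3 to compound 4 (0.91 log units; beyond the scatter) and moving from 4-methoxyphenyl to 3,4-dichlorophenyl brings a 40-fold lower number from compound 2 to compound 4 (1.61 log units; beyond the scatter) with compound 4 now holding the lowest number of the four. Nothing measured here explains why these phenyl groups differ so widely.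

Compound 4 carries both of its chlorines at once, so the compounds shown cannot say what each contributes alone, and a phenyl bearing one chlorine at either of those two places would separate them. Going by these compounds, it also remains open whether a bromo or trifluoromethyl group on this ring would follow the chlorines of compound 4 or the methoxy of compound 2.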